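The compounds below may be only part of what the source reports. "The series", "measured", "known", "first", "only" and "open" are said of these compounds alone.

Measured compounds:
Compound 1 `COc1cc(N(C)C(=O)c2cccc([N+](=O)[O-])c2)cc(OC)c1OC` gives in a functional assay on ONS-76 cells (Homo sapiens) for cytotoxicity, read by MTT assay, with a stated time of 72 h (on this read-out higher numbers stand for weaker inhibition and lower numbers for stronger inhibition), only a limit, >= 125000 nM.
Compound 2 `COc1cc(N(C)C(=O)N(C)c2ccc(F)cc2)cc(OC)c1OC` gives in this assay only a limit, >= 125000 nM.
Compound 3 `COc1cc(NC(=O)Nc2cccc(F)c2)cc(OC)c1OC` gives in this assay the number 65600 nM.

Compound 2 therefore stands at the edge of what this assay can report: its result is the limit of >= 125000 nM in this assay, at which 2 of the 3 values shown sit. Compound 1 shares that limit, and only compound 3 returns a number at all, a weak one. Among the measured compounds shown here, no pair of measured compounds differs in a single place, so there is no measured step to lean on for the move to compound 4 `COc1cc(N(C)C(=O)N(C)c2ccc([N+](=O)[O-])cc2)cc(OC)c1OC`. That move is nitro in place of fluoro on an aromatic carbon. For the measured compounds named here, compound 1 also carries a nitro group and sits at the limit, but it differs from compound 4 in more than one place, so its value shows only that a nitro-bearing member of this series can be without measurable effect.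

With compound 2 already at the limit, the step from compound 2 to compound 4 is expected to be none beyond the scatter, which the estimate a number no higher from compound 2 to compound 4 (the limit leaves the size open) expresses. Compound 4 is accordingly expected to give about 125000 nM in this assay, between 40000 nM and 400000 nM, most likely again reported only as a limit.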

Compound 4, half-maximal inhibitory concentration: >= 125000 nM
Compound 4 gave a limit, no number; the forecaster's own chance of this, stated with the estimate: 75%; the middle value lies on the limit itself.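

In this assay, compound 2 and compound 4 both return only a limit, so the step between them cannot be read: the limit of >= 125000 nM in this assay, at which 3 of the 4 values shown sit.

The compounds shown leave open whether nitro in place of fluoro on an aromatic carbon makes any difference on a scaffold that gives a number in this assay.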